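Hydroxy for chloro on the five-membered ring: compound 4

The source may report more compounds than this note shows. Statements on the series, on what has been measured and on what is new or still open speak of the compounds shown alone.

Compound 1 `O=c1[nH]c(=O)n(COCCO)cc1[N+](=O)[O-]`: 447 ug/mL
Compound 2 `CC(=O)OCCOCn1cnc2c(Cl)nc(N)nc21`: 91 ug/mL
Compound 3 `Nc1nc2c(nc(Cl)n2COCCO)c(=O)[nH]1`: 350 ug/mL

In a functional assay on L1210 cells (Mus musculus) for inhibition (a lower number here means a stronger inhibitor, a higher number a weaker inhibitor), compound 3 gives 350 ug/mL, the second highest of the three numbers. Compound 1 gives 447 ug/mL, within the scatter of compound 3, so the two cannot be ordered. Compound 2 gives 91 ug/mL, a lower number beyond the scatter. Compound 4 `Nc1nc2c(nc(O)n2COCCO)c(=O)[nH]1` is compound 3 with one change: hydroxy in place of chloro on an aromatic carbon. Among the compounds with values here, no step between measured compounds matches this change, so its size cannot be read from these data. In this assay the change is expected to move the number little, likely not beyond the scatter, with no clear direction. For compound 4 the estimate is 450 ug/mL, with a range from 150 ug/mL to 1400 ug/mL. The expected step of a 1.3-fold higher number from compound 3 to compound 4 (0.11 log units; within the scatter) is accordingly small.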

Compound 4, concentration for 50% inhibition: > 500 ug/mL
Compound 4: only a limit was reported; the forecaster's own chance of this, stated with the estimate: 25%; at least 1.1-fold (0.04 log units) between middle value and limit.
By their numbers in this assay, from the lowest: compound 2; then compounds 3 and 1 (each within the scatter of the next). At a limit, above all of these: compound 4.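

In this assay hydroxy in place of chloro gives an at least 1.4-fold higher number from compound 3 to compound 4 (0.15 log units; that floor lies within the scatter) as the first step read on this aromatic carbon between two ring nitrogen atoms. Compound 4 gives > 500 ug/mL in this reading, which is a limit and not a number. Going by these compounds, the true size of the step therefore stays unknown: its floor does not separate hydroxy from chloro, though hydroxy shows no gain in inhibition here.

An amine or a methyl group on the same carbon remains untested in the compounds shown. Also open, on these data alone, is how a longer chain in place of the (2-hydroxyethoxy)methyl group would read on this core.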